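Swapping Chloro for Trifluoromethyl Next to the Urea Nitrogen

A few compounds are considered here, and "the series" means these few. Any claim that something is new, unique, unknown or untested is made for them only; others in the source may bear on it.

For the measured compounds named here, compound 3 `O=C(Nc1cccc(-n2cc(-c3ccncc3)c(-c3ccc(Cl)c(O)c3)n2)c1)Nc1ccc(Cl)c(Cl)c1` gives 1190 nM in a functional assay on Malme-3M cells (Homo sapiens) for inhibition, read by sulforhodamine B assay, with a stated time of 48 h (on this read-out lower numbers stand for stronger inhibition of growth and higher numbers for weaker inhibition of growth), the highest of the three numbers so far, though within the usual scatter of both others. Compound 2 `COc1cc(-c2nn(-c3cccc(NC(=O)Nc4ccc(Cl)c(Cl)c4)c3)cc2-c2ccncc2)ccc1Cl` gives 926 nM; the step of a 1.3-fold higher number from compound 2 to compound 3 (0.11 log units; within the scatter) follows a single change, hydrogen in place of methyl on an oxygen on an aromatic ring. Compound 1 `COc1cc(-c2nn(-c3cccc(NC(=O)Nc4cc(C(F)(F)F)cc(C(F)(F)F)c4)c3)cc2-c2ccncc2)ccc1Cl` gives 892 nM, and the numbers of compound 1 and compound 2 differ little, even though compound 1 carries trifluoromethyl groups where compound 2 carries chloro groups. Compound 4 `O=C(Nc1cccc(-n2cc(-c3ccncc3)c(-c3ccc(Cl)c(O)c3)n2)c1)Nc1ccc(Cl)c(C(F)(F)F)c1` is compound 3 with trifluoromethyl in place of chloro on an aromatic carbon. No measured step isolates this exact swap, but the small gap between compound 1 and compound 2 gives no reason to expect much movement. Compound 4 is expected to show a step of a 1.1-fold lower number from compound 3 to compound 4 (0.05 log units; within the scatter), within the scatter. Compound 4 is therefore estimated at 1050 nM, with a range from 500 nM to 2200 nM.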

Compound 4, concentration for 50% growth inhibition: 576 nM
The estimate for compound 4 lay 1.8-fold (0.26 log units) above the measured number; the measured number falls inside the stated range.
By their numbers in this assay, from the lowest: compounds 4, 1, 2 and 3 (each within the scatter of the next, the first and the last beyond it).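

In this assay, for the compounds shown here, trifluoromethyl in place of chloro on this aromatic carbon gives a 2.1-fold lower number from compound 3 to compound 4 (0.32 log units; beyond the scatter), the only step between compounds differing in one place that lies beyond the scatter. So this carbon, ortho to a chloro group, responds to a change of group, though the step is modest. Nothing here explains the difference.

From the compounds shown here alone, whether a nitrile or a bromine on this same carbon would give a similar number remains open. So does whether the swap gives a similar step with methyl instead of hydrogen on the oxygen.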